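Aryl Swap on the Triazole Arm: Estimating Compound 4

The compounds below may be only part of what the source reports. "The series", "measured", "known", "first", "only" and "open" are said of these compounds alone.

Compound 1, `N#CC1=C(N)Oc2c(N)cc3nc4ccccc4nc3c2C12C(=O)N(Cc1cnnn1-c1ccccc1Cl)c1ccccc12`, gives > 50000 nM in a functional assay on HCT-116 cells (Homo sapiens) for antiproliferative activity, read by MTT assay, with a stated time of 48 h (a higher number here means a weaker inhibitor, a lower number a stronger inhibitor), a limit of the assay rather than a number.
Compound 2, `N#CC1=C(N)Oc2c(N)cc3nc4ccccc4nc3c2C12C(=O)N(Cc1cnnn1-c1cccc(C(F)(F)F)c1)c1ccccc12`, gives 18900 nM.
Compound 3, `CCOc1ccccc1-n1nncc1CN1C(=O)C2(C(C#N)=C(N)Oc3c(N)cc4nc5ccccc5nc4c32)c2ccccc21`, gives > 50000 nM, again a limit and not a number.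

Compound 3 therefore stands at the weak end of what is shown, sharing its position with one other compound (the limit of > 50000 nM in this assay, at which 2 of the 3 values shown sit). Compound 4, `Cc1ccc(C)c(-n2nncc2CN2C(=O)C3(C(C#N)=C(N)Oc4c(N)cc5nc6ccccc6nc5c43)c3ccccc32)c1`, differs from compound 3 in a single place: 2,5-dimethylphenyl in place of 2-ethoxyphenyl on an aromatic nitrogen. Two measured steps alter the same aryl group on the aromatic nitrogen and so bear on this change. First, an at least 2.6-fold lower number from compound 1 to compound 2 (0.42 log units; beyond the scatter). Second, an at least 2.6-fold higher number from compound 2 to compound 3 (0.42 log units; beyond the scatter). The remaining pair is less informative: a step that the two limits leave unreadable from compound 1 to compound 3. Taken together, the aryl group on the triazole can move the number, but only one of the three aryl groups shown brought the value under the limit, and compound 4 carries two methyl groups rather than the trifluoromethyl of compound 2. Within the data shown here, the expected outcome is therefore a small or no step, an at least 1.2-fold lower number from compound 3 to compound 4 (0.09 log units; that floor lies within the scatter), with a real chance that only a limit is reported again. Compound 4 is estimated at 40000 nM, in a range from 15000 nM to 120000 nM.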

Compound 4, half-maximal inhibitory concentration: > 50000 nM
Compound 4 was reported as a limit (the forecaster's own chance of this, stated with the estimate: 55%); middle value at least 1.2-fold (0.09 log units) away from the limit.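

Replacing the 3-(trifluoromethyl)phenyl of compound 2 with 2,5-dimethylphenyl gives an at least 2.6-fold higher number from compound 2 to compound 4 (0.42 log units; beyond the scatter) in this assay, so a third aryl group joins 2-chlorophenyl and 2-ethoxyphenyl in failing to give a number, and compound 2 stays alone with a measured value. Swapping 2-ethoxyphenyl for 2,5-dimethylphenyl removes the oxygen and the hydrogen-bond acceptor from this group, yet compound 4 is still reported only as a limit of the assay, and the steps among compound 1, compound 3 and compound 4 cannot be read, as each joins two limits. The set now gathers at one end of the scale: the limit of > 50000 nM in this assay, at which 3 of the 4 values shown sit.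

Going by these compounds, it remains open whether the trifluoromethyl group itself or its place in 3-(trifluoromethyl)phenyl sets compound 2 apart from the other three compounds. On these data alone, a 3-methylphenyl or a 2-(trifluoromethyl)phenyl group on the same nitrogen would separate these two readings, while how far compound 1, compound 3 and compound 4 actually lie past the limit stays unknown.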